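The compounds below may be only part of what the source reports. "The series", "measured", "known", "first", "only" and "open" are said of these compounds alone.

In a functional assay on the whole organism for antagonist activity, with Mus musculus as the target (a lower number here means that less compound is needed, a higher number that more compound is needed for the effect), compound 1 (`COC(=O)N(C)CC#CCn1ccnc1`) gives > 100 mg/kg, which is a limit of the assay and not a number. Its close relative, compound 2 (`COC(=O)N(C)C(C)C#CCn1ccnc1`), gives > 100 mg/kg, also a limit. The starting point is therefore known only as the limit of > 100 mg/kg in this assay, at which 2 of the 2 values shown sit. Compound 3 (`CCOC(=O)N(C)CC#CCn1ccnc1`) differs from compound 1 by methyl in place of hydrogen on a saturated chain carbon bound to an oxygen next to a carbonyl group, so that methoxycarbonyl becomes ethoxycarbonyl. Going by the values given here, the only measured step is a step that the two limits leave unreadable from compound 1 to compound 2. It adds a methyl elsewhere in the molecule and gives no size to carry over, so no clear direction can be expected in this assay. The expected change is small, with the estimated step being a step that the limit leaves unreadable from compound 1 to compound 3. For compound 3, the estimated dose is 130 mg/kg, with an expected range of 50 mg/kg to 300 mg/kg.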

Compound 3, dose for half-maximal effect: 97 mg/kg
Compound 3: middle estimate off by 1.3-fold (0.13 log units), on the high side, within the range that was stated.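

With ethoxycarbonyl in place of methoxycarbonyl, compound 3 gives 97 mg/kg in this assay, the first actual number among the compounds shown. Compound 1 gives > 100 mg/kg, which is a limit of the assay and not a number. Going by these compounds, the change can therefore be read only as an at least 1.0-fold lower number from compound 1 to compound 3 (0.01 log units; that floor lies within the scatter), so this position tolerates the added methyl, but the true size of the step remains unknown.

On these data alone, it remains open whether a longer chain, such as propyl or butyl in place of ethyl, would bring the dose further down, or whether the small gain in readability ends with ethyl. Any such comparison would start from a series that still mostly sits at the edge of what the assay can read: the limit of > 100 mg/kg in this assay, at which 2 of the 3 values shown sit.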